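This account rests on a few compounds, and the source may have more. Where it says the series, first, only, none or still open, it means among the compounds named here.

Of the compounds shown here, three built on one shared core have been measured in an ADME assay on MT4 cells (Homo sapiens) for cytotoxicity, read by MTT assay; a higher number here means that more compound is tolerated, a lower number that less compound is tolerated. Compound 1 `O=C1c2ccccc2C(=O)N1CCOC(=S)N(C(=O)c1ccc(C(F)(F)F)cc1)c1ccc(Cl)cc1` gives 10000 nM. Compound 2 `O=C1c2ccccc2C(=O)N1CCOC(=S)N(C(=O)c1cccc(F)c1F)c1ccc(Cl)cc1` gives 58000 nM, and compound 3 `O=C1c2ccccc2C(=O)N1CCOC(=S)N(C(=O)c1ccc(F)c(F)c1)c1ccc(Cl)cc1` gives 52000 nM. Compound 3 thus stands second highest of the three: the nearer step is a 1.1-fold lower number from compound 2 to compound 3 (0.05 log units; within the scatter), while the wider step is a 5.2-fold higher number from compound 1 to compound 3 (0.72 log units; beyond the scatter), matched by a 5.8-fold higher number from compound 1 to compound 2 (0.76 log units; beyond the scatter).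

Compound 4 `O=C1c2ccccc2C(=O)N1CCOC(=S)N(C(=O)c1ccc(Cl)c([N+](=O)[O-])c1)c1ccc(Cl)cc1` differs from compound 3 by 4-chloro-3-nitrophenyl in place of 3,4-difluorophenyl on a carbonyl carbon. Among the compounds with values here, no measured step covers this exchange directly. What the measured steps do show is that swapping the aryl group on this carbonyl carbon can move the number modestly, as in the step from compound 1 to the difluorophenyl pair, or leave it within the scatter, as between compound 2 and compound 3. Because the exchange of this aryl group produced a 5.2-fold higher number from compound 1 to compound 3 (0.72 log units; beyond the scatter), compound 4 is expected to move somewhat, most likely downward, a 1.7-fold lower number from compound 3 to compound 4 (0.24 log units; within the scatter). Compound 4 is therefore estimated at 30000 nM, within a range from 8000 nM to 90000 nM.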

Compound 4, half-maximal cytotoxic concentration: 48000 nM
The estimate for compound 4 lay 1.6-fold (0.20 log units) below the measured number; the measured number falls inside the stated range.
By their numbers in this assay, from the lowest: compound 1; then compounds 4, 3 and 2 (each within the scatter of the next).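

In this assay, within the data shown here, the 4-chloro-3-nitrophenyl group on this carbonyl carbon falls in with the two difluorophenyl groups: a 1.1-fold lower number from compound 3 to compound 4 (0.03 log units; within the scatter) and a 1.2-fold lower number from compound 2 to compound 4 (0.08 log units; within the scatter) are both small, while a 4.8-fold higher number from compound 1 to compound 4 (0.68 log units; beyond the scatter) is of a size close to the earlier steps from compound 1. Among the four aryl groups shown, only the 4-(trifluoromethyl)phenyl of compound 1 now stands apart, and a group with a chlorine and a nitro group in place of two fluorines leaves the number within the scatter of the difluorophenyl compounds. Nothing available gives a reason for this separation.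

The compounds shown leave open whether an unsubstituted phenyl, an aminophenyl or a carboxyphenyl on this carbonyl carbon would join this cluster or stand apart with compound 1. They also leave open whether a saturated alkyl chain could replace the aryl group here.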